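The source may report more compounds than this note shows. Statements on the series, on what has been measured and on what is new or still open speak of the compounds shown alone.

Of the compounds shown here, two have so far been tested in a functional assay on SMMC-7721 cells (Homo sapiens) for cytotoxicity, read by MTT assay, with a stated time of 48 h; a higher number here means a weaker inhibitor, a lower number a stronger inhibitor. The first is compound 1 `O=C(NC1CCC2(CC1)OCC1(CO2)C2CC3CC(C2)CC1C3)c1ccc(O)c(O)c1`. In this assay compound 1 gives > 50000 nM, which is a limit of the assay rather than a measured number. The second is compound 2 `O=C(NO)[C@H]1CC[C@]2(CC1)OO[C@]1(O2)C2CC3CC(C2)CC1C3`, built on a different core and ending in a hydroxycarbamoyl group. In this assay compound 2 gives > 50000 nM, again a limit of the assay and not a number. Both values sit at the limit of > 50000 nM in this assay, at which 2 of the 2 values shown sit, so neither compound has shown measurable cytotoxicity and no step between the two can be sized.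

Compound 3 `O=C(O)[C@H]1CC[C@]2(CC1)OO[C@]1(O2)C2CC3CC(C2)CC1C3` is compound 2 with a single change: hydroxy in place of hydroxyamino on a carbonyl carbon. Among the measured compounds shown here, no measured step guides this change, and the one known value for compound 2 is a limit. The step of a number no higher from compound 2 to compound 3 (the limit leaves the size open) is therefore expected to be none beyond the scatter. In this assay compound 3 is estimated at 50000 nM, with a range from 20000 nM to 100000 nM, and most likely the assay will again report only a limit.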

Compound 3, half-maximal inhibitory concentration: > 100000 nM
Compound 3 gave a limit, no number; the forecaster's own chance of this, stated with the estimate: 80%; middle value at least 2.0-fold (0.30 log units) away from the limit.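

Compound 3 gives > 100000 nM, which is a limit of the assay and not a number. Compound 2 also stands only at a limit, so no step can be read between compound 2 and compound 3. On these data alone, whether hydroxy in place of hydroxyamino on a carbonyl carbon changes cytotoxicity at all remains open.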